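The source may report more compounds than this note shows. Statements on the series, on what has been measured and on what is new or still open speak of the compounds shown alone.

Series notes. Compound 1 `CC(O)c1cccc(C(=O)N[C@@H](C)Cn2ccc(-c3ccc(C#N)c(Cl)c3)n2)c1` and compound 2 `C[C@@H](Cn1ccc(-c2ccc(C#N)c(Cl)c2)n1)NC(=O)c1ccccc1F` are amides on the shared core; compound 3 `C[C@@H](Cn1ccc(-c2ccc(C#N)c(Cl)c2)n1)Nc1ccc2cccnc2c1` carries an aryl amine instead. In an ADME assay on PC-3 cells (Homo sapiens) for cytotoxicity, read by CCK-8 assay, with a stated time of 6 days (a higher number here means a weaker inhibitor, a lower number a stronger inhibitor), compound 1 gives only a limit, > 30000 nM. Compound 2 likewise gives only a limit in this assay, > 30000 nM. Compound 3 gives 11200 nM in this assay. The step that the two limits leave unreadable from compound 1 to compound 2 cannot be read, as both compounds sit at the limit of > 30000 nM in this assay, at which 2 of the 3 values shown sit. Compound 4 `C[C@@H](Cn1ccc(-c2ccc(C#N)c(Cl)c2)n1)Nc1ncnc2nc[nH]c12` is the next member: a group of 9 heavy atoms (5 carbon, 4 nitrogen; one five-membered aromatic ring with 2 hetero atoms, one six-membered aromatic ring with 2 hetero atoms) in place of a group of 9 heavy atoms (7 carbon, 1 oxygen, 1 fluorine; one six-membered aromatic ring of carbon only), on an amine nitrogen. Within the data shown here, no measured step spans this change; the only number off the limit belongs to compound 3, also an aryl amine. Compound 4 is therefore expected to land near that figure, at an estimated 18000 nM within 7000 nM to 30000 nM. The step this expectation implies, an at least 1.6-fold lower number from compound 2 to compound 4 (0.22 log units; that floor lies within the scatter), starts from a limit and stays unreadable.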

Compound 4, half-maximal inhibitory concentration: 14100 nM
Compound 4: middle estimate off by 1.3-fold (0.11 log units), on the high side; the measured number falls inside the stated range.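

In this assay, among these compounds, the group with one five-membered and one six-membered aromatic ring, in place of (2-fluorophenyl)carbonyl on the amine nitrogen, gives the first readable step: an at least 2.1-fold lower number from compound 2 to compound 4 (0.32 log units; beyond the scatter). The full size of that step cannot be read, because compound 2 gives only a limit: the limit of > 30000 nM in this assay, at which 2 of the 4 values shown sit. Compound 3 gives 11200 nM and compound 4 gives 14100 nM, so both aryl amines carry numbers where amide compounds 1 and 2 do not. Going by these compounds, whether loss of the carbonyl or the new ring system drives the step remains open. A plain phenyl on the amine nitrogen would separate the two.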